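Swapping an Ethynyl for an Acetoxy Group

The source may report more compounds than this note shows. Statements on the series, on what has been measured and on what is new or still open speak of the compounds shown alone.

Compound 3 `C#Cc1ccn2cc(-c3ccc(NC(=O)Nc4cc(C(C)(C)C)on4)cc3)nc2c1` gives 3.46 nM in a functional assay on MV4-11 cells (Homo sapiens) for cytotoxicity, read by MTT assay, with a stated time of 72 h (on this read-out higher numbers stand for weaker inhibition and lower numbers for stronger inhibition), the second highest of the three numbers here. Its nearest neighbour is compound 2 `Cc1ccn2cc(-c3ccc(NC(=O)Nc4cc(C(C)(C)C)on4)cc3)nc2c1`, which gives 0.79 nM, and the furthest is compound 1 `CC(C)(C)c1cc(NC(=O)Nc2ccc(-c3cn4ccncc4n3)cc2)no1`, which carries nothing at that place and gives 44.8 nM. Compound 4 `CC(=O)Oc1ccn2cc(-c3ccc(NC(=O)Nc4cc(C(C)(C)C)on4)cc3)nc2c1` differs from compound 3 by acetoxy in place of ethynyl on an aromatic carbon. Among the compounds with values here, the only measured step at this place is a 4.4-fold higher number from compound 2 to compound 3 (0.64 log units; beyond the scatter). That step was modest, so a modest step, most likely towards a higher number, is expected for compound 4 as well. Compound 4 is therefore expected to give 8 nM, somewhere between 2 nM and 40 nM, which means a 2.3-fold higher number from compound 3 to compound 4 (0.36 log units; beyond the scatter).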

Compound 4, half-maximal inhibitory concentration: 29.4 nM
The estimate for compound 4 lay 3.7-fold (0.57 log units) below the measured number, and the stated range covers the measured number.
By their numbers in this assay, from the lowest: compound 2; then compound 3; then compounds 4 and 1 (each within the scatter of the next).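

In this assay, acetoxy at this position gives an 8.5-fold higher number from compound 3 to compound 4 (0.93 log units; beyond the scatter) and a 37-fold higher number from compound 2 to compound 4 (1.57 log units; beyond the scatter) and so widens the span of numbers well beyond what methyl and ethynyl alone showed. Among these three groups on this aromatic carbon, the order from lowest number runs methyl, ethynyl, acetoxy, the only one of them with hydrogen-bond acceptors. Nothing available explains why acetoxy gives the highest number here. A methoxy group or an amine at this place could show whether an oxygen on the ring goes with the higher number, and a longer carbon chain whether group size alone tracks it.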